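The source may hold more compounds than are shown below. What is called first, only, known or untested is meant among the compounds shown, and "the series" means these compounds.

Among the compounds with values here, compound 1 `COc1ccccc1C(=O)NC(=O)Nc1ccc(N2CCCCC2)c(C(F)(F)F)c1` is one of two compounds measured in an in vitro ADME assay on microsomes from liver (Rattus norvegicus) for metabolic stability, with a stated time of 30 min; a higher number here means faster removal of the compound, a lower number slower removal; in this assay compound 1 gives 26 mL.min-1.g-1. Within the data shown here, the only other measured compound is compound 2 `COc1ccccc1C(=O)NC(=O)Nc1ccc(-c2ccccn2)c(C(F)(F)F)c1`, which differs from compound 1 by a pyridin-2-yl in place of piperidin-1-yl on an aromatic carbon; in this assay compound 2 gives 15 mL.min-1.g-1, and the step of a 1.7-fold lower number from compound 1 to compound 2 (0.24 log units; within the scatter) lies within the scatter, so the two numbers cannot be told apart.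

Compound 3 `COc1ccccc1C(=O)NC(=O)Nc1ccc(N2CCCCC2)c(Cl)c1` keeps the piperidin-1-yl group of compound 1 and changes a different position: chloro in place of trifluoromethyl on an aromatic carbon. Among the measured compounds shown here, no measured step touches the trifluoromethyl, so the single step recorded, from compound 1 to compound 2 at another position, gives no direct guide; it shows only that one change on this ring left the number within the scatter. The expectation is therefore a step of a 1.2-fold higher number from compound 1 to compound 3 (0.06 log units; within the scatter) that stays within the scatter, and compound 3 is estimated to give 30 mL.min-1.g-1, with a range from 12 mL.min-1.g-1 to 75 mL.min-1.g-1.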

Compound 3, intrinsic clearance in microsomes: 36 mL.min-1.g-1
The estimate for compound 3 lay 1.2-fold (0.08 log units) below the measured number; the measured number falls inside the stated range.
By their numbers in this assay, from the lowest: compounds 2, 1 and 3 (each within the scatter of the next, the first and the last beyond it).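

At the position ortho to a piperidin-1-yl group, chloro in place of trifluoromethyl gives a 1.4-fold higher number from compound 1 to compound 3 (0.14 log units; within the scatter) in this assay, so the two compounds cannot be told apart. Within the data shown here, this is the first measured change at this position, and it shows that replacing a group of 4 heavy atoms with one of 1 heavy atom leaves the read-out within the scatter for this pair. No measurement here offers an explanation for this result.

The compounds shown leave open whether a nitrile, a methyl group or an amine at this position would also stay within the scatter. They also leave open whether chloro would give a similar result with pyridin-2-yl in place of piperidin-1-yl.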